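Dropping a Trifluoromethyl from an Amide at the Limit

The source may hold more compounds than are shown below. What is called first, only, known or untested is meant among the compounds shown, and "the series" means these compounds.

Compound 1 `COc1cc(-c2nn(-c3cccc(NC(=O)c4cccc(C(F)(F)F)c4)c3)cc2-c2ccncc2)ccc1Cl` is an amide that, in a functional assay on IGROV-1 cells (Homo sapiens) for inhibition, read by sulforhodamine B assay, with a stated time of 48 h (on this read-out higher numbers stand for weaker inhibition of growth and lower numbers for stronger inhibition of growth), gives only a limit rather than a number: compound 1 reaches > 50000 nM. That is where (the limit of > 50000 nM in this assay, at which 1 of the 2 values shown sits). A second compound, compound 2 `O=C(Nc1cccc(-n2cc(-c3ccncc3)c(-c3ccc(Cl)c(O)c3)n2)c1)Nc1cc(C(F)(F)F)cc(C(F)(F)F)c1`, is built differently in several places, and in this assay compound 2 gives 3550 nM. Within the data shown here, no single-change step links compound 1 and compound 2, so their two values show only that compound 2 has a number while compound 1 does not.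

Compound 3 `COc1cc(-c2nn(-c3cccc(NC(=O)c4ccccc4)c3)cc2-c2ccncc2)ccc1Cl` differs from compound 1 in one place: hydrogen in place of trifluoromethyl on an aromatic carbon. Because compound 1 stands at the limit of > 50000 nM in this assay, at which 1 of the 2 values shown sits, the effect of this change can only be judged as moving into the measurable range or staying beyond it. Among the measured compounds shown here, with no measured step of this kind to lean on, the expected change is a step that the limit leaves unreadable from compound 1 to compound 3, and compound 3 is most likely to sit at a limit again. Compound 3 is therefore estimated at 60000 nM, within a range from 15000 nM to 200000 nM.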

Compound 3, concentration for total growth inhibition: > 100000 nM
Compound 3 was reported as a limit; the forecaster's own chance of this, stated with the estimate: 70%; at least 1.6-fold (0.22 log units) between middle value and limit.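

Compound 1 and compound 3 both give only a limit rather than a number, so no step can be read for hydrogen in place of trifluoromethyl. The compounds shown leave open whether this change alters growth inhibition at all, and if it does, in which direction and by how much.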